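A few compounds are considered here, and "the series" means these few. Any claim that something is new, unique, unknown or untested is made for them only; others in the source may bear on it.

Within the data shown here, compound 3 `CC1=NC(C)=C(C(=O)O)C(c2cccc(Cl)c2)/C1=C(\O)OC/C=C/C1CCCCC1` gives 3.7 nM in a functional assay on thoracic aorta for inhibition of Voltage-gated L-type calcium channel (Rattus norvegicus) (a higher number here means a weaker inhibitor, a lower number a stronger inhibitor), the lowest of the three numbers measured so far. Compound 2 `CC1=NC(C)=C(C(=O)O)C(c2cccnc2)/C1=C(\O)OC/C=C/c1ccccc1` gives 190 nM and compound 1 `COC(=O)c1cccc(C2C(C(=O)O)=C(C)N=C(C)/C2=C(/O)OC/C=C/c2ccccc2)c1` gives 4400 nM; both values stand far above that of compound 3. Compound 4 `CC1=NC(C)=C(C(=O)O)C(c2cccc(Cl)c2)/C1=C(\O)OCc1ccc2ccccc2c1` differs from compound 3 only in the ester side chain: naphthalen-2-yl in place of 2-cyclohexylethenyl on a saturated chain carbon bound to an oxygen on an unsaturated carbon. Among the measured compounds shown here, no measured step touches this place. For the measured compounds named here, the single measured step, a 23-fold lower number from compound 1 to compound 2 (1.36 log units; beyond the scatter), concerns the aryl group on the saturated ring carbon and carries no information about the ester chain, so the expectation for this assay rests on the change itself and amounts to no shift clearly beyond the scatter. Compound 4 is therefore expected to give 8 nM, within 2 nM to 40 nM. The expected step is a 2.2-fold higher number from compound 3 to compound 4 (0.33 log units; beyond the scatter).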

Compound 4, half-maximal inhibitory concentration: 14 nM
Compound 4: middle estimate off by 1.8-fold (0.24 log units), on the low side; the range from low to high includes it.
By their numbers in this assay, from the lowest: compound 3; then compound 4; then compound 2; then compound 1.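

The ester side chain now has its first measured step: in this assay, naphthalen-2-yl in place of 2-cyclohexylethenyl gives a 3.8-fold higher number from compound 3 to compound 4 (0.58 log units; beyond the scatter). The step is modest, so this position accepts an all-aromatic group in place of the ring-bearing alkene with only a limited loss, in contrast to the large step seen at the aryl group on the saturated ring carbon. No supporting data explain this difference. Still open, from the compounds shown here alone, is how an amine or a carboxylic acid on the ester chain would read. Also open, going by these compounds, is whether this step holds with pyridin-3-yl on the saturated ring carbon.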